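Side chain swap from compound 2 to compound 3

The source may hold more compounds than are shown below. What is called first, only, known or untested is meant among the compounds shown, and "the series" means these compounds.

- Compound 1 `O=C(NCCCNc1c(C(=O)NCc2ccc(F)cc2)nc(Br)c2cccnc12)c1ccccc1`: > 10000 nM, a limit
- Compound 2 `O=C(NCc1ccc(F)cc1)c1nc(Br)c2cccnc2c1N1CCNCC1`: 4500 nM

Going by the values given here, in a functional assay on LNCaP cells (Homo sapiens) for cytotoxicity, read by MTT assay, with a stated time of 72 h (on this read-out lower numbers stand for stronger inhibition and higher numbers for weaker inhibition), compound 2 gives 4500 nM, the only number so far. Compound 1 gives only a limit, > 10000 nM. Compound 3 `NCCCCCCNc1c(C(=O)NCc2ccc(F)cc2)nc(Br)c2cccnc12` has (6-aminohexyl)amino in place of piperazin-1-yl on an aromatic carbon, para to a bromo group ((6-aminohexyl)amino in place of piperazin-1-yl on an aromatic carbon). Among the compounds with values here, no measured step covers this change, so no step beyond the scatter is expected in this assay, and no direction is favoured. For compound 3 the expected value is 4000 nM, within an estimated range of 1200 nM to 10000 nM. The expected step is a 1.1-fold lower number from compound 2 to compound 3 (0.05 log units; within the scatter).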

Compound 3, half-maximal inhibitory concentration: 8000 nM
Estimate against measurement, compound 3: 2.0-fold (0.30 log units) below, and the stated range covers the measured number.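

In this assay, (6-aminohexyl)amino in place of piperazin-1-yl on the aromatic carbon para to a bromo group gives a 1.8-fold higher number from compound 2 to compound 3 (0.25 log units; within the scatter), so the open chain and the ring are not separated at this position. The comparison with the benzamido-capped chain gives an at least 1.2-fold lower number from compound 1 to compound 3 (0.09 log units; that floor lies within the scatter), so that change is not separated from the scatter either. Compound 1 is held at a limit of the assay, not a number: the limit of > 10000 nM in this assay, at which 1 of the 3 values shown sits.

Open, from the compounds shown here alone, is whether a carboxylic acid at the chain end, or a methyl group on the piperazine nitrogen, would move the number beyond the scatter in this assay.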